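A few compounds are considered here, and "the series" means these few. Any claim that something is new, unique, unknown or untested is made for them only; others in the source may bear on it.

Measured so far:
compound 1, `Oc1cccc(-c2cc(-c3ccc(F)cc3)cc(-c3cccc(O)c3)n2)c1` — 6310 nM
compound 2, `Oc1ccc(-c2cc(-c3ccc(F)cc3)cc(-c3cccc(O)c3)n2)cc1` — 5020 nM
compound 3, `Oc1cccc(-c2cc(-c3cccc(OC(F)(F)F)c3)cc(-c3ccccc3O)n2)c1` — 2740 nM

The three measured compounds were tested in a functional assay on HCT-15 cells (Homo sapiens) for inhibition; a lower number here means a stronger inhibitor, a higher number a weaker inhibitor. Among the measured compounds shown here, compound 1 and compound 2 share one core; the only change between them is 4-hydroxyphenyl in place of 3-hydroxyphenyl on an aromatic carbon, and the step it made was a 1.3-fold lower number from compound 1 to compound 2 (0.10 log units; within the scatter). Compound 3 rests on a different core; how the two cores differ is not broken down here. In this assay compound 3 gives a lower number than compound 1, while its value and that of compound 2 lie within the scatter of each other.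

Compound 4, `Oc1ccc(-c2cc(-c3cccc(OC(F)(F)F)c3)cc(-c3ccccc3O)n2)cc1`, has not yet been measured. It arises from compound 3 by 4-hydroxyphenyl in place of 3-hydroxyphenyl on an aromatic carbon. For the measured compounds named here, this is the same kind of change as the one from compound 1 to compound 2, though its surroundings differ: in compound 1 the place is meta to a 3-hydroxyphenyl group and meta to a 4-fluorophenyl group, in compound 3 it is meta to a 2-hydroxyphenyl group and meta to a large group. Since the earlier step stayed within the scatter, the step from compound 3 to compound 4 is expected to be small as well, about a 1.2-fold lower number from compound 3 to compound 4 (0.10 log units; within the scatter). Compound 4 is therefore estimated at 2200 nM, likely between 1000 nM and 4800 nM in this assay.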

Compound 4, half-maximal inhibitory concentration: > 50000 nM
Compound 4: no number, only a limit; the forecaster's own chance of this, stated with the estimate: 5%; at least 22-fold (1.35 log units) between middle value and limit.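

In this assay, compound 4 gives only a limit of the assay, > 50000 nM, and not a number. Putting 4-hydroxyphenyl in place of 3-hydroxyphenyl changed little on the core of compound 1 but made a large difference on the core of compound 3, an at least 18-fold higher number from compound 3 to compound 4 (1.26 log units; beyond the scatter), so the effect of this change did not carry over from one core to the other: the same change on two cores in this assay, a 1.3-fold lower number (0.10 log units; within the scatter) from compound 1 to compound 2 and an at least 18-fold higher number (1.26 log units; beyond the scatter) from compound 3 to compound 4, at least 22-fold (1.36 log units) apart, beyond the scatter of two such steps This shows that, in this series, the step seen on one core is a poor guide to the step on another, but it does not show why the two cores respond differently or how large the step really is, with only a limit for compound 4.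

The compounds shown leave open whether the 2-hydroxyphenyl group, the trifluoromethoxy group or both make the core of compound 3 so sensitive to this change. They also leave open how an amine or a carboxylic acid in place of the hydroxyl group would fare on either core.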